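The compounds below may be only part of what the source reports. "The series", "measured", "known", "first", "only" and "open" are said of these compounds alone.

Compound 2, with the structure `Cc1n[nH]c(C(=O)O)c1Cc1ccc(C(F)(F)F)cc1`, was examined in an assay on isolated protein for inhibition of 2-Hydroxyacid oxidase 2 (Homo sapiens), tested at 1 uM (on this read-out lower numbers stand for a weaker effect and higher numbers for a stronger effect at the one concentration tested), where compound 2 gives 9%. Its two companions share the same core with different groups on the methylene-linked ring: compound 1, with the structure `Cc1n[nH]c(C(=O)O)c1Cc1ccc2ccccc2n1`, gives 2% in this assay, and compound 3, with the structure `Cc1n[nH]c(C(=O)O)c1Cc1cccc(C(N)=O)c1`, gives 8%. All three numbers are low, and compound 2 is not separated from either compound 3 or compound 1 by more than the usual scatter of this kind of measurement, so nothing in these three points to one of them standing apart.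

The next compound, compound 4 with the structure `Cc1n[nH]c(C(=O)O)c1Cc1ccc(C#N)cc1`, differs from compound 2 in a single place: cyano in place of trifluoromethyl on an aromatic carbon. Within the data shown here, no step between two measured compounds is available to guide the expectation, and none of the three measured compounds rises above the scatter. The expected step from compound 2 to compound 4 in this assay is therefore a number 3 percentage points lower from compound 2 to compound 4 (within the scatter), that is, none beyond the scatter. Compound 4 is estimated to give 6% in this assay, with a likely range from 0% to 18%.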

Compound 4, a percentage reported as inhibition, at one concentration (the size of the read-out at that concentration, not a potency): 0%
Compound 4: middle estimate off by 6 percentage points, on the high side; the range from low to high includes it.
By their numbers in this assay, from the lowest: compounds 4, 1, 3 and 2 (each within the scatter of the next).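

Cyano in place of trifluoromethyl gives the first step in this series between two compounds that differ in one place: in this assay, the step is a number 9 percentage points lower from compound 2 to compound 4 (within the scatter). On this aromatic carbon, para to a large group, the exchange therefore does not separate the two compounds, and neither group lifts the read-out out of the low range shared by the whole series. Nothing measured here bears on this result.

Going by these compounds, whether any group at this place can raise the read-out beyond the scatter remains open, for example an amine, a hydroxyl group or a longer alkyl chain in place of cyano. Also open, on these data alone, is whether the low numbers belong to the shared core or to the groups tested on the methylene-linked ring so far.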